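Adding cyclopropylcarbonyl to compound 3: a real change?

The source may hold more compounds than are shown below. What is called first, only, known or untested is meant among the compounds shown, and "the series" means these compounds.

- compound 1 `Nc1nc2ccc(-c3cn([C@@H]4CN[C@H](C(=O)Nc5ccc(Cl)c(C(F)(F)F)c5)C4)nn3)nc2s1` gives 26200 nM
- compound 2 `O=C(Nc1nc2ccc(-c3cn([C@@H]4CN[C@H](C(=O)Nc5ccc(Cl)c(C(F)(F)F)c5)C4)nn3)nc2s1)C1CC1` gives 16200 nM
- compound 3 `Nc1nc2ccc(-c3cn([C@@H]4CN[C@H](C(=O)Nc5ccc(Br)cc5)C4)nn3)nc2s1` gives 24400 nM
- compound 4 `O=C(Nc1nc2ccc(-c3cn([C@@H]4CN[C@H](C(=O)Nc5ccc(Br)cc5)C4)nn3)nc2s1)C1CC1` is not yet measured

All three values come from a functional assay on K562 cells (Homo sapiens) for inhibition, read by MTT assay, with a stated time of 48 h; on this read-out lower numbers stand for stronger inhibition and higher numbers for weaker inhibition. There, compound 3 gives 24400 nM, which lies within the usual scatter of both other compounds, so the three cannot be put in a meaningful order.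

Compound 4 differs from compound 3 in one place: cyclopropylcarbonyl in place of hydrogen on a nitrogen on an aromatic ring. In plain terms, cyclopropylcarbonyl replaces hydrogen on a nitrogen on an aromatic ring, so amino becomes (cyclopropylcarbonyl)amino.

The same change has been measured once, as a 1.6-fold lower number from compound 1 to compound 2 (0.21 log units; within the scatter). The other measured step, a 1.1-fold lower number from compound 1 to compound 3 (0.03 log units; within the scatter), swaps 4-chloro-3-(trifluoromethyl)phenyl for 4-bromophenyl, so compound 3 and compound 1 differ only in that group. This makes the first step a fair guide, although a single pair is thin evidence.

The expected result is therefore a similar small move, a 1.6-fold lower number from compound 3 to compound 4 (0.20 log units; within the scatter), which is no step beyond the scatter. For compound 4 the estimated value in this assay is 15500 nM, with an expected range from 8000 nM to 30000 nM.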

Compound 4, half-maximal inhibitory concentration: 8160 nM
For compound 4 the middle estimate is 1.9-fold (0.28 log units) above the measured one; low and high end bracket the measured number.
By their numbers in this assay, from the lowest: compounds 4, 2, 3 and 1 (each within the scatter of the next, the first and the last beyond it).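

In this assay, putting cyclopropylcarbonyl on the nitrogen of the amino group now gives a step that clears the usual scatter, a 3.0-fold lower number from compound 3 to compound 4 (0.48 log units; beyond the scatter), which the first pair carrying this change did not do. Even so, the larger step should not be read as a different behaviour on this core, since the two pairs agree within the scatter of two such steps: the same change on two cores in this assay, a 1.6-fold lower number (0.21 log units; within the scatter) from compound 1 to compound 2 and a 3.0-fold lower number (0.48 log units; beyond the scatter) from compound 3 to compound 4, 1.8-fold (0.27 log units) apart, within the scatter of two such steps With cyclopropylcarbonyl in place, swapping 4-chloro-3-(trifluoromethyl)phenyl for 4-bromophenyl on the amide-type nitrogen gives a 2.0-fold lower number from compound 2 to compound 4 (0.30 log units; within the scatter), so this swap stays inside the scatter on both cores: the same change on two cores in this assay, a 1.1-fold lower number (0.03 log units; within the scatter) from compound 1 to compound 3 and a 2.0-fold lower number (0.30 log units; within the scatter) from compound 2 to compound 4, 1.8-fold (0.27 log units) apart, within the scatter of two such steps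

Cyclopropylcarbonyl is the only group shown on this nitrogen apart from hydrogen, so it remains open whether the step needs the three-membered ring or whether a plain acetyl, a benzoyl or a longer acyl chain would serve as well. Two pairs also cannot settle how large the step truly is, or whether it holds on aryl groups other than these two.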